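This account rests on a few compounds, and the source may have more. Where it says the series, first, only, none or still open, it means among the compounds named here.

Measured so far: compound 3 `Cc1n[nH]c(C(=O)O)c1Cc1ccc(C(N)=O)cc1` with 1100 nM in an assay on isolated protein for inhibition of 2-Hydroxyacid oxidase 2 (Rattus norvegicus); on this read-out lower numbers stand for stronger inhibition and higher numbers for weaker inhibition; compound 1 `Cc1n[nH]c(C(=O)O)c1Cc1ccc(Oc2ccccc2)cc1` with 500 nM; compound 2 `Cc1n[nH]c(C(=O)O)c1Cc1cccc(-c2ccccc2F)c1` with 900 nM.

Compound 3 gives the highest of the three numbers, though compound 2 lies within the scatter of it, and compound 1 is the only one clearly apart. Compound 4 `Cc1n[nH]c(C(=O)O)c1Cc1ccc(-c2ccc(F)cc2)cc1` is reached from compound 3 by 4-fluorophenyl in place of carbamoyl on an aromatic carbon. Within the data shown here, the one measured step that bears on this is a 2.2-fold higher number from compound 1 to compound 3 (0.34 log units; beyond the scatter), where a phenoxy group at the same place gave the lower number. Compound 4 carries a 4-fluorophenyl group there, so a step back toward compound 1 is expected, a 2.0-fold lower number from compound 3 to compound 4 (0.30 log units; within the scatter). Compound 4 is therefore estimated at 550 nM, with a range from 200 nM to 1500 nM.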

Compound 4, half-maximal inhibitory concentration: 400 nM
Compound 4: the middle estimate sits 1.4-fold (0.14 log units) above what was measured; the measured number falls inside the stated range.
By their numbers in this assay, from the lowest: compounds 4, 1, 2 and 3 (each within the scatter of the next, the first and the last beyond it).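

At this aromatic carbon, a 2.8-fold lower number from compound 3 to compound 4 (0.44 log units; beyond the scatter) in this assay separates the 4-fluorophenyl group from carbamoyl, so a second route away from carbamoyl now gives a lower number, this time through an aromatic ring attached directly. Against phenoxy the same group shows no readable difference, with a 1.3-fold lower number from compound 1 to compound 4 (0.10 log units; within the scatter) in this assay, so these two aromatic groups cannot be ranked. Nothing available explains these results. The compounds shown leave open whether an amine or a carboxylic acid at this carbon would track carbamoyl or the aromatic groups. Also open, from the compounds shown here alone, is what an unsubstituted phenyl group would give here.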